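Amide aryl replacement: thiophene to furan, compound 3 to 4

The source may hold more compounds than are shown below. What is called first, only, known or untested is meant among the compounds shown, and "the series" means these compounds.

The series keeps the core shown for compound 1 `Cc1cc(C(=O)N[C@H]2CCN(Cc3ccc(OCCCN(C)C)cc3)C2)ccc1Br` and varies the aryl group on the carbonyl carbon. In an assay on HEK293 cells for binding affinity to Urotensin-2 receptor (Homo sapiens), read by radioligand binding (on this read-out higher numbers stand for weaker inhibition and lower numbers for stronger inhibition), compound 1 gives 631 nM. Compound 2 `CN(C)CCCOc1ccc(CN2CC[C@H](NC(=O)c3ccc(C(F)(F)F)cc3)C2)cc1` is recorded in this assay only as a limit, < 10000 nM. Compound 3 `CN(C)CCCOc1ccc(CN2CC[C@H](NC(=O)c3cccs3)C2)cc1` likewise stands in this assay only at a limit, < 10000 nM. Because of the limit of < 10000 nM in this assay, at which 2 of the 3 values shown sit, the measured steps on this position cannot be sized: a step that the limit leaves unreadable from compound 1 to compound 2, a step that the limit leaves unreadable from compound 1 to compound 3 and a step that the two limits leave unreadable from compound 2 to compound 3 all remain unreadable.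

Compound 4 `CN(C)CCCOc1ccc(CN2CC[C@H](NC(=O)c3ccco3)C2)cc1` differs from compound 3 by furan-2-yl in place of thiophen-2-yl on a carbonyl carbon. No readable step bears on this change, so neither a size nor a direction can be drawn from the measured compounds. The step in this assay is therefore expected as a step that the limit leaves unreadable from compound 3 to compound 4, with the limit itself the most likely outcome. For compound 4 the estimate in this assay is 5000 nM, within 1000 nM to 20000 nM.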

Compound 4, inhibition constant: < 10000 nM
Compound 4: no number, only a limit; the forecaster's own chance of this, stated with the estimate: 70%; the middle value is on the limit's open side.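

Compound 4 is recorded in this assay only as a limit, < 10000 nM. Its steps from compound 1, compound 2 and compound 3 cannot be read because of the limit: the limit of < 10000 nM in this assay, at which 3 of the 4 values shown sit. The compounds shown leave open whether furan-2-yl, thiophen-2-yl and 4-(trifluoromethyl)phenyl on a carbonyl carbon differ at all.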